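Swapping Amino for Phenyl: Expected Cytotoxicity of Compound 4

The source may report more compounds than this note shows. Statements on the series, on what has been measured and on what is new or still open speak of the compounds shown alone.

Compound 1 `Cc1nnc(Sc2c(C)oc3ccccc3c2=O)o1` gives > 50000 nM in a functional assay on HEp-2 cells (Homo sapiens) for cytotoxicity, read by MTT assay, with a stated time of 72 h; on this read-out higher numbers stand for weaker inhibition and lower numbers for stronger inhibition; this is a limit of the assay, not a number.
Compound 2 `Cc1cc(C)n2nc(SCc3nnc(SCc4coc5ccccc5c4=O)n3N)nc2n1` gives 7100 nM in this assay.
Compound 3 `Cc1nnc(SCc2coc3ccc(Cl)cc3c2=O)s1` gives 4200 nM in this assay.

Going by the values given here, only two of the three compounds give actual numbers. Compound 2 and compound 3 sit close together, within the usual scatter of repeated measurements, so neither can be called stronger or weaker than the other. Compound 1 contributes only a limit (the limit of > 50000 nM in this assay, at which 1 of the 3 values shown sits).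

Compound 4 `Cc1cc(C)n2nc(SCc3nnc(SCc4coc5ccccc5c4=O)n3-c3ccccc3)nc2n1` is not yet measured. It differs from compound 2 in one place: phenyl in place of amino on an aromatic nitrogen. Among the compounds with values here, no measured pair in this set shows a change of this kind, so there is no direct guide to the size or direction of the step. With nothing to lean on, the safest expectation is a step of modest size, not clearly beyond the scatter, in either direction.

Compound 4 is therefore expected to give about 6000 nM in this assay, with a range from 2000 nM to 20000 nM. This corresponds to an expected step of a 1.2-fold lower number from compound 2 to compound 4 (0.07 log units; within the scatter).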

Compound 4, half-maximal inhibitory concentration: 22100 nM
Compound 4: middle estimate off by 3.7-fold (0.57 log units), on the low side; the whole stated range lies below it.
By their numbers in this assay, from the lowest: compounds 3 and 2 (each within the scatter of the next); then compound 4. At a limit, above all of these: compound 1.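

In this assay putting phenyl in place of amino on this aromatic nitrogen gives a 3.1-fold higher number from compound 2 to compound 4 (0.49 log units; beyond the scatter) and so weaker inhibition. Going by these compounds alone, this is the first one-place change in the set, and it shows that the position responds to what it carries: the compound with the six-membered carbon ring and no hydrogen-bond donor in this group is the weaker of the pair. No measurement shown bears on the reason for this step.

From the compounds shown here alone, it remains open how a small group such as methyl, or a ring such as pyridyl, would fare on this nitrogen, which could help separate the number of atoms entering from the loss of the donor. Going by these compounds, it is also open whether the same swap would give a similar step on a different core.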